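This account rests on a few compounds, and the source may have more. Where it says the series, first, only, none or still open, it means among the compounds named here.

Measured so far:
compound 1, `Clc1ccccc1-c1ccc2[nH]ncc2c1`: 1230 nM
compound 2, `Cc1ccccc1-c1ccc2[nH]ncc2c1`: 7810 nM

In an assay on CHO-TREX cells for antagonist activity at transient receptor potential cation channel subfamily A member 1 (Homo sapiens), read by FLIPR and calcium flux, with a stated time of 10 min (on this read-out higher numbers stand for weaker inhibition and lower numbers for stronger inhibition), compound 2 gives the highest of the two numbers; its nearest neighbour is compound 1, and a 6.3-fold higher number from compound 1 to compound 2 (0.80 log units; beyond the scatter) separates them. Compound 3, `FC(F)(F)Oc1ccccc1-c1ccc2[nH]ncc2c1`, is not yet measured. It differs from compound 2 by trifluoromethoxy in place of methyl on an aromatic carbon. Going by the values given here, no measured step exchanges methyl for trifluoromethoxy, and the single step known, a 6.3-fold higher number from compound 1 to compound 2 (0.80 log units; beyond the scatter), concerns a different group at this place, so it gives only loose guidance. Compound 3 is therefore expected to land between the two measured numbers, giving an estimated 2.6-fold lower number from compound 2 to compound 3 (0.42 log units; beyond the scatter), so that compound 3 is estimated at 3000 nM with a range from 800 nM to 12000 nM.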

Compound 3, half-maximal inhibitory concentration: 3430 nM
Compound 3: middle estimate off by 1.1-fold (0.06 log units), on the low side; the measured number falls inside the stated range.
By their numbers in this assay, from the lowest: compound 1; then compound 3; then compound 2.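

In this assay, this place on the ring accepts a group larger than methyl with no loss: trifluoromethoxy gives a 2.3-fold lower number from compound 2 to compound 3 (0.36 log units; beyond the scatter), a modest gain. It does not match chloro, however, with a 2.8-fold higher number from compound 1 to compound 3 (0.45 log units; beyond the scatter), so chloro keeps the lowest number of the three. Nothing measured here explains this order. From the compounds shown here alone, whether an amine, a carboxylic acid or a longer chain such as ethoxy would fare better at this place remains open. So does whether chloro would keep its lead elsewhere on the same ring.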